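A few compounds are considered here, and "the series" means these few. Any claim that something is new, unique, unknown or untested is made for them only; others in the source may bear on it.

Measured compounds in a functional assay on RPMI-8226 cells (Homo sapiens) for inhibition, read by sulforhodamine B assay, with a stated time of 48 h; on this read-out lower numbers stand for higher toxicity in this test and higher numbers for lower toxicity in this test:

Compound 1 `O=C(Nc1cccc(-n2cc(-c3ccncc3)c(-c3ccc(Cl)c(O)c3)n2)c1)Nc1cccc(C(F)(F)F)c1` gives > 32500 nM; this is a limit of the assay, not a number.
Compound 2 `O=C(Nc1cccc(-n2cc(-c3ccncc3)c(-c3ccc(Cl)c(O)c3)n2)c1)Nc1ccc(Cl)c(Cl)c1` gives > 32500 nM, again a limit of the assay.
Compound 3 `COc1cc(-c2nn(-c3cccc(NC(=O)Nc4ccc(Cl)c(C(F)(F)F)c4)c3)cc2-c2ccncc2)ccc1Cl` gives > 32500 nM, also a limit of the assay.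

Working notes on the series. All three measured compounds sit at the same limit, so in this assay nothing separates them: the limit of > 32500 nM in this assay, at which 3 of the 3 values shown sit. Going by the values given here, the one step between measured compounds that differ in one place, a step that the two limits leave unreadable from compound 1 to compound 2, is unreadable for the same reason, since both ends are limits. Compound 3 thus stands where every other measured compound stands, at the limit, with no readable number.

Compound 4 `O=C(Nc1cccc(-n2cc(-c3ccncc3)c(-c3ccc(Cl)c(O)c3)n2)c1)Nc1ccc(Cl)c(C(F)(F)F)c1` differs from compound 3 by hydrogen in place of methyl on an oxygen on an aromatic ring. Among the compounds with values here, no measured step bears directly on this change; the only measured step, from compound 1 to compound 2, concerns a different part of the molecule and is itself unreadable. The expectation therefore rests on the shared limit alone, and the expected step that the limit leaves unreadable from compound 3 to compound 4 is none beyond the scatter. Compound 4 is estimated to give 40000 nM in this assay, with a range from 15000 nM to 120000 nM, most likely reported again as a limit.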

Compound 4, concentration lethal to 50% of the cells: > 32500 nM
Compound 4 was reported as a limit (the forecaster's own chance of this, stated with the estimate: 80%); the middle value does not contradict the limit.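

No new step can be read among compound 1, compound 2, compound 3 and compound 4, because each value is a limit of the assay: the limit of > 32500 nM in this assay, at which 4 of the 4 values shown sit. The compounds shown leave open whether the read-out in this assay responds at all to methoxy to hydroxy or to the other changes on the shared core.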